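The source may hold more compounds than are shown below. What is called first, only, known or untested is meant among the compounds shown, and "the series" means these compounds.

Working notes on the series. Compound 1 `O=[N+]([O-])c1ccc(-c2nc3cc(Cl)c(Cl)cc3[nH]2)cc1` is measured in an ADME assay on Vero cells (Chlorocebus sabaeus) for cytotoxicity; on this read-out higher numbers stand for lower toxicity in this test and lower numbers for higher toxicity in this test; compound 1 gives >= 100000 nM, which is a limit of the assay and not a number. Compound 2 `Cn1c(-c2ccc([N+](=O)[O-])cc2)nc2cc(C(F)(F)F)ccc21` gives > 100000 nM in this assay, again a limit rather than a number. Compound 3 `O=[N+]([O-])c1ccc(-c2nc3cc(C(F)(F)F)ccc3n2C2CCCCC2)cc1` gives > 100000 nM in this assay, also a limit. Compound 2 therefore stands at the limit of > 100000 nM in this assay, at which 2 of the 3 values shown sit, where compound 3 also sits, while compound 1 sits at the limit of >= 100000 nM in this assay, at which 1 of the 3 values shown sits. Among the measured compounds shown here, the one measured step, a step that the two limits leave unreadable from compound 2 to compound 3, has both ends at a limit and gives no readable size.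

Compound 4 `CCC(=O)Nc1ccc(-c2nc3cc(C(F)(F)F)ccc3n2C)cc1` is not yet measured. It differs from compound 2 by propanoylamino in place of nitro on an aromatic carbon. For the measured compounds named here, no measured step touches this change, and the single step that is measured concerns a substituent on an aromatic nitrogen, not this position, and is itself unreadable. With every value in the set sitting at a limit, no step beyond the scatter is expected in this assay in either direction. The step from compound 2 to compound 4 is expected to be a number no higher from compound 2 to compound 4 (the limit leaves the size open). Compound 4 is therefore estimated at 100000 nM, in the range 30000 nM to 300000 nM, most likely reported again as a limit.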

Compound 4, half-maximal cytotoxic concentration: > 100000 nM
Compound 4 ended at the assay's limit; the forecaster's own chance of this, stated with the estimate: 70%; the middle value sits exactly at the limit.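

In this assay compound 2 and compound 4 both stand at a limit, and the step between them cannot be read. The compounds shown leave open where the true values of all four lie, and whether propanoylamino in place of nitro shifts the read-out at all.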